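Swapping the cyclopropylmethyl arm for propyl on the amine

A few compounds are considered here, and "the series" means these few. Any claim that something is new, unique, unknown or untested is made for them only; others in the source may bear on it.

Measured compounds:
compound 1 `CCN(Cc1c(C(F)(F)F)nc2n(-c3c(C)cc(C)cc3C)c(Cl)cn12)CC1CC1` — 9 nM
compound 2 `Cc1cc(C)c(-n2c(Cl)cn3c(CN(CCC(F)(F)F)CC4CC4)c(C(F)(F)F)nc23)c(C)c1` — 16 nM

In an assay on cells for displacement of a labelled ligand from corticotropin-releasing factor receptor 1 (Homo sapiens), with a stated time of 100 min (on this read-out lower numbers stand for stronger inhibition and higher numbers for weaker inhibition), compound 1 gives 9 nM, and compound 2 gives 16 nM. The two values lie within the scatter of each other, as the step of a 1.8-fold higher number from compound 1 to compound 2 (0.25 log units; within the scatter) shows; compound 2 therefore stands level with compound 1 rather than apart from it.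

Compound 3 `CCCN(CCC(F)(F)F)Cc1c(C(F)(F)F)nc2n(-c3c(C)cc(C)cc3C)c(Cl)cn12` is the unmeasured partner of compound 2. The change is ethyl in place of cyclopropyl on a saturated chain carbon bound to an amine nitrogen. Among the measured compounds shown here, the only measured step, a 1.8-fold higher number from compound 1 to compound 2 (0.25 log units; within the scatter), concerns a different position of the molecule and says nothing about this exchange; the data hold no step on the amine arm itself. The expectation for compound 3 is therefore a step of about a 1.4-fold higher number from compound 2 to compound 3 (0.14 log units; within the scatter), not beyond the scatter. Compound 3 is expected to give 22 nM, with a range from 8 nM to 60 nM.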

Compound 3, inhibition constant: 12 nM
Compound 3: the middle estimate sits 1.8-fold (0.26 log units) above what was measured; measured number inside the range.
By their numbers in this assay, from the lowest: compounds 1, 3 and 2 (each within the scatter of the next).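

On the amine arm itself, the exchange of cyclopropyl for ethyl now has a reading in this assay: it gives a 1.3-fold lower number from compound 2 to compound 3 (0.12 log units; within the scatter) and so shows that, with the 3,3,3-trifluoropropyl arm held fixed, the three-membered ring can give way to an open chain without a shift beyond the scatter. The wider exchange of the whole amino group gives a 1.3-fold higher number from compound 1 to compound 3 (0.12 log units; within the scatter) and likewise stays within the scatter, so compound 1, compound 2 and compound 3 stand level. Nothing at hand gives a reason for this result.

The compounds shown leave open whether a longer chain such as butyl, or a larger ring such as cyclobutylmethyl, would stay level on this amine. They also leave open how an arm carrying a hydroxyl group or an ether oxygen would read here.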